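Methylamino for Methyl on Compound 2

A few compounds are considered here, and "the series" means these few. Any claim that something is new, unique, unknown or untested is made for them only; others in the source may bear on it.

In an ADME assay on MDCK-II cells (Canis lupus familiaris) for permeability (on this read-out lower numbers stand for lower permeability and higher numbers for higher permeability), compound 1 `CC(C)Oc1cc(Oc2ccc(S(C)(=O)=O)cc2)cc(-c2cncc(=O)[nH]2)c1` gives 94 10^-6 cm/s and compound 2 `CC(C)Oc1cc(Oc2ccc(S(C)(=O)=O)cc2)cc(-c2nccc(=O)[nH]2)c1` gives 24 10^-6 cm/s, so compound 2 holds the lower of the two numbers. Compound 3 `CNS(=O)(=O)c1ccc(Oc2cc(OC(C)C)cc(-c3nccc(=O)[nH]3)c2)cc1` differs from compound 2 by a single change: methylamino in place of methyl on a sulfonyl sulfur. In words, methylamino stands in place of methyl on a sulfonyl sulfur. Among the compounds with values here, only one measured step exists, a 3.9-fold lower number from compound 1 to compound 2 (0.59 log units; beyond the scatter), and it swaps one ring group for another while leaving the sulfonyl group untouched. That step shows how far one change has moved this assay here, but it does not test this change, so the direction remains a judgement. A modest fall is expected, an estimated 1.7-fold lower number from compound 2 to compound 3 (0.23 log units; within the scatter). For compound 3 the expected value is 14 10^-6 cm/s, with an estimated range from 6 10^-6 cm/s to 28 10^-6 cm/s.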

Compound 3, apparent permeability: 15 10^-6 cm/s
Estimate against measurement, compound 3: 1.1-fold (0.03 log units) below; low and high end bracket the measured number.
By their numbers in this assay, from the lowest: compounds 3 and 2 (each within the scatter of the next); then compound 1.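

In this assay, methylamino in place of methyl on a sulfonyl sulfur gives a 1.6-fold lower number from compound 2 to compound 3 (0.20 log units; within the scatter), so this pair cannot be told apart from no shift at all. Within the data shown here, this is the first look at the sulfonyl end of the molecule, and here the swap, which brings in a nitrogen and a hydrogen-bond donor, stays inside the scatter, whereas the ring swap, a 3.9-fold lower number from compound 1 to compound 2 (0.59 log units; beyond the scatter), lies beyond it. No measurement here offers an explanation for this result.

This single pair leaves open whether a plain amino, a dimethylamino or a longer chain such as ethylamino on the same sulfur would also stay within the scatter. It also leaves open whether methylamino would behave the same way on the core of compound 1, which carries the other ring.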